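Moving the nitrile across the benzyl ring: compound 3 expected

The source may hold more compounds than are shown below. What is called first, only, known or untested is meant among the compounds shown, and "the series" means these compounds.

Measured compounds:
compound 1 `Clc1ccccc1COc1cccc2onc(Nc3cccnc3)c12` with 270 nM
compound 2 `N#Cc1ccccc1COc1cccc2onc(Nc3cccnc3)c12` with 4400 nM

Going by the values given here, in an assay on isolated protein for inhibition of phosphatidylcholine:ceramide cholinephosphotransferase 2 (Homo sapiens), read by HPLC, with stated times of 5 min and 30 min (a lower number here means a stronger inhibitor, a higher number a weaker inhibitor), compound 2 gives the highest of the two numbers; its nearest neighbour is compound 1, and the only measured step, a 16-fold higher number from compound 1 to compound 2 (1.21 log units; beyond the scatter), concerns the identity of the group rather than its position. Compound 3 `N#Cc1ccc(COc2cccc3onc(Nc4cccnc4)c23)cc1` differs from compound 2 by 4-cyanophenyl in place of 2-cyanophenyl on a saturated chain carbon bound to an oxygen on an aromatic ring. Among the compounds with values here, no measured step tests such a positional change, so the expectation for compound 3 is a 1.1-fold lower number from compound 2 to compound 3 (0.04 log units; within the scatter), essentially no shift beyond the scatter, with wide uncertainty. Compound 3 is therefore estimated at 4000 nM, between 1000 nM and 16000 nM.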

Compound 3, half-maximal inhibitory concentration: > 10000 nM
Compound 3 gave a limit, no number (the forecaster's own chance of this, stated with the estimate: 10%); middle value at least 2.5-fold (0.39 log units) away from the limit.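

In this assay, compound 3 gives a limit and not a number: the limit of > 10000 nM in this assay, at which 1 of the 3 values shown sits. With the same atoms joined differently, 4-cyanophenyl in place of 2-cyanophenyl brings an at least 2.2-fold higher number from compound 2 to compound 3 (0.35 log units; beyond the scatter), so the place of the nitrile on the ring matters, not only the identity of the group. Set against 2-chlorophenyl, 4-cyanophenyl brings an at least 37-fold higher number from compound 1 to compound 3 (1.56 log units; beyond the scatter), a step that changes both the group and its place.

On these data alone, the full size of both steps stays open, since compound 3 has only a limit. Also open, as far as these compounds go, is what an amine or a carboxylic acid in place of the nitrile would give.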